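Taking the chloro off compound 1

This account rests on a few compounds, and the source may have more. Where it says the series, first, only, none or still open, it means among the compounds named here.

Compound 1 (`Clc1cccc(/N=N/N2CCCC2)c1`) was tested in an ADME assay on MT4 cells (Homo sapiens) for cytotoxicity, read by MTT assay, with a stated time of 96 h (on this read-out higher numbers stand for lower toxicity in this test and lower numbers for higher toxicity in this test), and gave > 100000 nM, which is a limit of the assay and not a number. Its standing therefore rests on (the limit of > 100000 nM in this assay, at which 1 of the 2 values shown sits). Compound 2 (`CCOC(=O)N1CCN(/N=N/c2ccccc2)CC1`), the other tested compound, returned an actual number in this assay of 100000 nM.

Compound 3 (`c1ccc(/N=N/N2CCCC2)cc1`) is still to be measured in this assay. It differs from compound 1 in a single place: hydrogen in place of chloro on an aromatic carbon, with hydrogen in place of chloro on an aromatic carbon. Among the measured compounds shown here, no pair of tested compounds shows what such a change does in this assay, and the only two readings available both lie at the top of the range. A step no larger than the usual scatter is therefore expected, with no direction favoured, and compound 3 may well come back as a limit too. The estimated step is a number no higher from compound 1 to compound 3 (the limit leaves the size open). For compound 3 the expected value is 100000 nM, with an estimated range of 30000 nM to 200000 nM.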

Compound 3, half-maximal cytotoxic concentration: > 100000 nM
Compound 3 ended at the assay's limit; the forecaster's own chance of this, stated with the estimate: 60%; the middle value lies on the limit itself.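

In this assay compound 3 gives > 100000 nM, which is a limit of the assay and not a number. Compound 1 also stands at a limit, so no step can be read between compound 1 and compound 3: the limit of > 100000 nM in this assay, at which 2 of the 3 values shown sit. The compounds shown leave open whether hydrogen in place of chloro on an aromatic carbon changes cytotoxicity at all.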